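Series notes: cyclopropylethynyl in place of thiophenyl

This account rests on a few compounds, and the source may have more. Where it says the series, first, only, none or still open, it means among the compounds named here.

Measured so far:
compound 1, `O=c1[nH]c(=O)n(CCC(CO)CO)cc1-c1cccs1`: 6000 nM
compound 2, `CC(=O)OCC(CCn1cc(C#Cc2cc(F)cc(F)c2)c(=O)n(C(=O)c2ccccc2)c1=O)COC(C)=O`: 28900 nM
compound 3, `CC(=O)OCC(CCn1cc(C#CC2CC2)c(=O)n(C(=O)c2ccccc2)c1=O)COC(C)=O`: 100 nM

In a functional assay on MCF7 cells (Homo sapiens) for antiproliferative activity, read by MTT assay, with a stated time of 72 h (on this read-out higher numbers stand for weaker inhibition and lower numbers for stronger inhibition), compound 1 stands second highest of the three numbers; compound 2 gives a higher number and compound 3 a far lower one. Compound 4, `O=c1[nH]c(=O)n(CCC(CO)CO)cc1C#CC1CC1`, carries the change (2-cyclopropylethynyl in place of thiophen-2-yl on an aromatic carbon). For the measured compounds named here, the only measured step that bears on it is a 290-fold lower number from compound 2 to compound 3 (2.46 log units; beyond the scatter), which sets a cyclopropyl on a triple-bonded carbon of a core that is not that of compound 1; the change here instead removes thiophen-2-yl and adds the whole 2-cyclopropylethynyl group, so the step is not the same. A lower number is expected for compound 4, though a smaller move than that step, because compound 3 gives 100 nM on a core that also differs from compound 1. For compound 4 the expected step is a 10-fold lower number from compound 1 to compound 4 (1.00 log units; beyond the scatter), to an estimated 600 nM with range 120 nM to 3000 nM.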

Compound 4, half-maximal inhibitory concentration: > 100000 nM
Compound 4: a limit, no number; the forecaster's own chance of this, stated with the estimate: 5%; at least 160-fold (2.22 log units) between middle value and limit.
By their numbers in this assay, from the lowest: compound 3; then compound 1; then compound 2. At a limit, above all of these: compound 4.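

In this assay, 2-cyclopropylethynyl in place of thiophen-2-yl on this aromatic carbon of the shared core gives an at least 16-fold higher number from compound 1 to compound 4 (1.22 log units; beyond the scatter). The value of compound 4 is a limit, not a number: the limit of > 100000 nM in this assay, at which 1 of the 4 values shown sits.

Cyclopropyl gave a 290-fold lower number from compound 2 to compound 3 (2.46 log units; beyond the scatter) on a different core; on the core of compound 1 the direction is reversed. As far as these compounds go, whether the benzoyl and acetate groups of compound 2 and compound 3 decide that direction stays open. Also open, from the compounds shown here alone, is how a longer alkyl chain or an amine in place of cyclopropyl on the triple-bonded carbon would read on the core of compound 1.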